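The source may hold more compounds than are shown below. What is called first, only, known or untested is meant among the compounds shown, and "the series" means these compounds.

Working notes on the series. Compound 1 `Cc1ccc(-n2cc(CN3C(=O)C[C@@H]4CC[C@@]3(C)C4(C)C)nn2)cc1` gives 390 nM in a functional assay on SGC-7901 cells (Homo sapiens) for inhibition, read by MTT assay, with a stated time of 24 h; on this read-out higher numbers stand for weaker inhibition and lower numbers for stronger inhibition. Compound 2 `CC1(C)[C@H]2CC[C@]1(C)N(Cc1cn(-c3ccccc3C#N)nn1)C(=O)C2` gives 260 nM in this assay, and compound 3 `CC1(C)[C@H]2CC[C@]1(C)N(Cc1cn(-c3ccc(F)cc3)nn1)C(=O)C2` gives 500 nM in this assay. Compound 3 holds the highest of the three numbers, its nearest neighbour being compound 1 and its furthest compound 2, yet both gaps lie within the scatter: a 1.3-fold higher number from compound 1 to compound 3 (0.11 log units; within the scatter) and a 1.9-fold higher number from compound 2 to compound 3 (0.28 log units; within the scatter). The remaining measured step, a 1.5-fold lower number from compound 1 to compound 2 (0.18 log units; within the scatter), is likewise within the scatter.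

Compound 4 `Cc1cccc(-n2cc(CN3C(=O)C[C@@H]4CC[C@@]3(C)C4(C)C)nn2)c1` has not yet been measured. The change from compound 3 is 3-methylphenyl in place of 4-fluorophenyl on an aromatic nitrogen. The step that bears most closely is a 1.3-fold higher number from compound 1 to compound 3 (0.11 log units; within the scatter), in which fluoro and methyl were exchanged on an aromatic carbon; in compound 4 the methyl is placed as 3-methylphenyl rather than the 4-methylphenyl of compound 1, so that step guides only by analogy. The exchange of the whole aryl group in a 1.9-fold higher number from compound 2 to compound 3 (0.28 log units; within the scatter) also stayed within the scatter. Among the compounds with values here, no measured step on this aromatic nitrogen leaves the scatter, so none beyond it is expected in this assay either, the estimate amounting to a 1.3-fold lower number from compound 3 to compound 4 (0.10 log units; within the scatter). Compound 4 is therefore estimated at 400 nM, with a range from 200 nM to 800 nM.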

Compound 4, half-maximal inhibitory concentration: 410 nM
Beside the measured number, compound 4's estimate is 1.0-fold (0.01 log units) below it, within the range that was stated.
By their numbers in this assay, from the lowest: compounds 2, 1, 4 and 3 (each within the scatter of the next).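

Within the data shown here, compound 4 adds something the earlier compounds did not cover, the place of the methyl on the phenyl group: in this assay, 3-methylphenyl in place of 4-methylphenyl on the aromatic nitrogen gives a step within the scatter (a 1.1-fold higher number from compound 1 to compound 4 (0.02 log units; within the scatter)). The two other aryl exchanges at this nitrogen also stay within the scatter (a 1.2-fold lower number from compound 3 to compound 4 (0.09 log units; within the scatter); a 1.6-fold higher number from compound 2 to compound 4 (0.20 log units; within the scatter)), so 4-methylphenyl, 3-methylphenyl, 4-fluorophenyl and 2-cyanophenyl all lie within the scatter of one another, and the data separate none of these groups at this position. Nothing further is available to explain this lack of separation.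

All four compounds carry a phenyl group with a single substituent on the same core, so the series does not show whether an amine or a carboxylic acid on that phenyl group would give a step beyond the scatter. It also leaves open what a saturated group such as cyclohexyl, or a longer chain such as n-hexyl, would do on this aromatic nitrogen in place of the phenyl group.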